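A few compounds are considered here, and "the series" means these few. Any claim that something is new, unique, unknown or untested is made for them only; others in the source may bear on it.

Measured so far in an ADME assay on RAW264.7 cells (Mus musculus) for cytotoxicity, read by MTT assay, with a stated time of 72 h, tested at 50 uM; on this read-out lower numbers stand for less inhibition and higher numbers for more inhibition at the one concentration tested (going by the name of the read-out):

Compound 1 `CCOC(=O)c1sc(-c2ccccn2)nc1N1CCC(NCc2ccc(Cl)c(Cl)c2)CC1` gives 30.1%
Compound 2 `CCOC(=O)c1sc(-c2ccccn2)nc1N1CCC(NCc2ccc(Cl)cc2Cl)CC1` gives 18.6%
Compound 3 `CCOC(=O)c1sc(-c2ccncc2)nc1N1CCC(NCc2ccc(Cl)c(Cl)c2)CC1` gives 32.2%

Compound 1 and compound 3 share everything except the core difference (pyridin-4-yl in place of pyridin-2-yl on an aromatic carbon); that change reads a number 2.1 percentage points higher from compound 1 to compound 3 (within the scatter), so the two cores cannot be told apart on this read-out. Compound 1 and compound 2 differ by 2,4-dichlorophenyl in place of 3,4-dichlorophenyl on a saturated chain carbon bound to an amine nitrogen, and that change reads a number 11.5 percentage points lower from compound 1 to compound 2 (beyond the scatter), a modest but real drop in inhibition. Compound 3 and compound 2 differ in both places at once; their numbers lie beyond the scatter of each other, in the direction set by the benzyl change.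

Compound 4 `CCOC(=O)c1sc(-c2ccncc2)nc1N1CCC(NCc2ccc(Cl)cc2Cl)CC1` has not yet been run in this assay . It differs from compound 3 by 2,4-dichlorophenyl in place of 3,4-dichlorophenyl on a saturated chain carbon bound to an amine nitrogen, the same change as from compound 1 to compound 2, at the same place. Because the core difference gave a number 2.1 percentage points higher from compound 1 to compound 3 (within the scatter), the benzyl change is expected to carry over: the step from compound 3 to compound 4 is estimated as a number 11.2 percentage points lower from compound 3 to compound 4 (beyond the scatter), close to a number 11.5 percentage points lower from compound 1 to compound 2 (beyond the scatter). Compound 4 is therefore expected to give about 21%, with a likely range from 11% to 31%.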

Compound 4, a percentage reported as inhibition, at one concentration (the size of the read-out at that concentration, not a potency): 18.4%
Compound 4: the middle estimate sits 2.6 percentage points above what was measured, and the stated range covers the measured number.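

In this assay, 2,4-dichlorophenyl in place of 3,4-dichlorophenyl gives a number 13.8 percentage points lower from compound 3 to compound 4 (beyond the scatter), and this step carries over from the core of compound 1 to the core of compound 3: the same change on two cores in this assay, a number 11.5 percentage points lower (beyond the scatter) from compound 1 to compound 2 and a number 13.8 percentage points lower (beyond the scatter) from compound 3 to compound 4, 2.3 percentage points apart, within the scatter of two such steps

Pyridin-4-yl in place of pyridin-2-yl gives a number 0.2 percentage points lower from compound 2 to compound 4 (within the scatter), so this change does not separate the compounds with either dichlorophenyl group: the same change on two cores in this assay, a number 2.1 percentage points higher (within the scatter) from compound 1 to compound 3 and a number 0.2 percentage points lower (within the scatter) from compound 2 to compound 4, 2.3 percentage points apart, within the scatter of two such steps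

This agreement rests on two cores and one pair of dichlorophenyl groups, so it shows additive behaviour for these four compounds only, and a reading at one concentration gives no potency and no reason for the drop.

Still open, as far as these compounds go, is whether the step holds when the ethyl ester is replaced by a carboxylic acid or an amide. Also open, from the compounds shown here alone, is how the read-out responds when the chlorines on the benzyl ring are replaced by fluorine or methoxy groups.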